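Amino to Cyano: a Step from a Weak Starting Point

The compounds below may be only part of what the source reports. "The series", "measured", "known", "first", "only" and "open" are said of these compounds alone.

Three measured compounds set the scene:
compound 1 `COC(=O)C1=C(C)N=C(C)/C(=C(\O)OC)C1c1ccccc1N`: 39800 nM
compound 2 `COC(=O)C1=C(C)NC(C)=C(C(=O)OC)C1c1ccccc1`: 28.2 nM
compound 3 `COC(=O)C1=C(C)N=C(C)/C(=C(\O)OC)C1c1cc(OC)c(OC)cc1OC`: 1000000 nM

In a functional assay (muscle tissue) with Cavia porcellus as the target (a higher number here means that more compound is needed for the effect, a lower number that less compound is needed), compound 1 stands second highest of the three numbers. Its nearest neighbour on the scale is compound 3, whose number is higher by a gap that lies beyond the scatter; compound 2 sits far lower, also beyond the scatter. No two of these compounds differ in only one place, so the values alone are what they show.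

The unmeasured compound 4 `COC(=O)C1=C(C)N=C(C)/C(=C(\O)OC)C1c1ccccc1C#N` keeps the core of compound 1 and differs from it in one spot: cyano in place of amino on an aromatic carbon. Going by the values given here, no measured pair tracks this exact change, so the size of the step is open. Compound 1 is a weak starting point, and compound 2 shows that this core can reach a very low number in this assay. The expectation is a moderate step down, an 8.0-fold lower number from compound 1 to compound 4 (0.90 log units; beyond the scatter), beyond the scatter. Compound 4 is thus estimated at 5000 nM, with a range from 600 nM to 40000 nM.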

Compound 4, half-maximal effective concentration: 15.9 nM
Compound 4: middle estimate off by 310-fold (2.50 log units), on the high side, and the stated range ends above it.
By their numbers in this assay, from the lowest: compounds 4 and 2 (each within the scatter of the next); then compound 1; then compound 3.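

Changing only the group on this aromatic carbon, ortho to a large group, has a very large effect: in this assay the change from 2-aminophenyl to 2-cyanophenyl gives a 2500-fold lower number from compound 1 to compound 4 (3.40 log units; beyond the scatter) and lies far beyond the usual scatter. The weak number of compound 1 therefore does not come from the shared core alone, as one change at this place is enough to remove it. Counted from the structures, the swap removes a hydrogen-bond donor and keeps a hydrogen-bond acceptor, but no measurement here links either count to the size of the step, and nothing shown gives a reason for it.

As far as these compounds go, it remains open whether a nitro group or a carboxylic acid on this same carbon would give a number as low as that of compound 4. Also open, from the compounds shown here alone, is whether cyano in place of amino would produce a step of this size elsewhere on the aromatic ring.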